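The source may report more compounds than this note shows. Statements on the series, on what has been measured and on what is new or still open speak of the compounds shown alone.

Measured to date:
- compound 1, `O=C(O)c1cnc2c(F)cccc2c1`: 150 mg/kg in a functional assay on the whole organism (strain Sprague-Dawley) for inhibition, with Rattus norvegicus as the target; on this read-out higher numbers stand for an effect only at larger amounts of compound and lower numbers for an effect already at smaller amounts
- compound 2, `COc1cccc2cc(C(=O)O)cnc12`: 150 mg/kg
- compound 3, `CCc1cccc2cc(C(=O)O)cnc12`: 75 mg/kg

Compound 2 stands level with compound 1 at the digits shown, and the two share the highest number of the three; compound 3 is nearest to it only in the sense that it gives the lone different figure, the step from compound 2 to compound 3 being a 2.0-fold lower number from compound 2 to compound 3 (0.30 log units; within the scatter). The other two steps, no change at the digits printed from compound 1 to compound 2 (within the scatter) and a 2.0-fold lower number from compound 1 to compound 3 (0.30 log units; within the scatter), are likewise within the scatter. Every exchange of the single substituent on the carbon ring of the shared core has thus left this assay unmoved beyond its noise.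

Compound 4, `COc1ccc(OC)c2ncc(C(=O)O)cc12`, differs from compound 2 by methoxy in place of hydrogen on an aromatic carbon. Within the data shown here, no measured step adds a second group to the core, so the bearing of the three steps is indirect: they show only that the carbon ring tolerates fluoro, methoxy and ethyl alike. On that basis no step beyond the scatter is expected, and the estimated step is no change at the digits printed from compound 2 to compound 4 (within the scatter). Compound 4 is accordingly estimated at 150 mg/kg, with a range of 75 mg/kg to 300 mg/kg.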

Compound 4, minimum effective dose: > 50 mg/kg
Compound 4 ended at the assay's limit (the forecaster's own chance of this, stated with the estimate: 15%); the middle value does not contradict the limit.
By their numbers in this assay, from the lowest: compounds 3, 1 and 2 (each within the scatter of the next).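

In this assay compound 4 gives > 50 mg/kg as a limit, not a number. No step from compound 2 to compound 4 can be read: the limit of > 50 mg/kg in this assay, at which 1 of the 4 values shown sits.

The compounds shown leave open whether methoxy in place of hydrogen on an aromatic carbon moves the minimum effective dose of compound 2 at all.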